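A Second Chlorine and Cell Toxicity

The source may report more compounds than this note shows. Statements on the series, on what has been measured and on what is new or still open speak of the compounds shown alone.

Compound 2 `ClCc1ccccc1Cn1cnc2c(Cl)ncnc21` and compound 1 `ClCc1ccccc1Cn1cnc2c(Cl)nc(Cl)nc21` share a core and differ in one group: chloro in place of hydrogen on an aromatic carbon. In a functional assay on SW-620 cells (Homo sapiens) for cytotoxicity, read by sulforhodamine B assay, with a stated time of 48 h (on this read-out lower numbers stand for higher toxicity in this test and higher numbers for lower toxicity in this test), compound 2 gives 26300 nM, while compound 1 gives 810 nM, which is a 32-fold lower number from compound 2 to compound 1 (1.51 log units; beyond the scatter). Compound 3 `ClCc1cccc(Cn2cnc3ncnc(Cl)c32)c1` is built from the same atoms as compound 2, joined differently; the difference between the two cores is not broken down here. In this assay compound 3 gives 7410 nM. Compound 4 `ClCc1cccc(Cn2cnc3nc(Cl)nc(Cl)c32)c1` has not yet been measured; it differs from compound 3 by chloro in place of hydrogen on an aromatic carbon, the same change that turns compound 2 into compound 1. A step of similar size is expected, because the earlier change gave a 32-fold lower number from compound 2 to compound 1 (1.51 log units; beyond the scatter). The expected step is a 30-fold lower number from compound 3 to compound 4 (1.47 log units; beyond the scatter). Compound 4 is therefore estimated at about 250 nM, likely between 80 nM and 800 nM.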

Compound 4, concentration lethal to 50% of the cells: 4070 nM
Beside the measured number, compound 4's estimate is 16-fold (1.21 log units) below it; the whole stated range lies below it.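

On the core of compound 3, chloro in place of hydrogen gives a 1.8-fold lower number from compound 3 to compound 4 (0.26 log units; within the scatter) in this assay, so the large step seen on the other core does not reappear here. The size of this change therefore does not carry over from one core to the other in this series: the same change on two cores in this assay, a 32-fold lower number (1.51 log units; beyond the scatter) from compound 2 to compound 1 and a 1.8-fold lower number (0.26 log units; within the scatter) from compound 3 to compound 4, 18-fold (1.25 log units) apart, beyond the scatter of two such steps. These two pairs show that the step depends on the core, but they do not show which difference between the cores matters or what the change would do on a further core.

Among the compounds shown, only hydrogen and chloro sit on the carbon between two ring nitrogen atoms. Going by these compounds, how an amine or a methoxy group at that place would behave on either core remains open.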